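This account rests on a few compounds, and the source may have more. Where it says the series, first, only, none or still open, it means among the compounds named here.

Measured compounds in this assay:
compound 1 `CC(=O)Nc1ccc(S(=O)(=O)NNc2ccc(C#N)cc2)cc1`: 1390 nM
compound 2 `CC(=O)Nc1ccc(S(=O)(=O)NNc2ccc(Br)c(C)c2)cc1`: 130 nM
compound 3 `N#Cc1ccc(S(=O)(=O)NNc2ccc(Br)cc2)cc1`: 134 nM

In an assay on HeLa cells for inhibition of Indoleamine 2,3-dioxygenase 1 (Homo sapiens), read by spectrophotometry, with a stated time of 24 h (on this read-out lower numbers stand for an effect already at smaller amounts and higher numbers for an effect only at larger amounts of compound), compound 3 gives 134 nM, the second highest of the three numbers; compound 2 gives 130 nM, which lies within the scatter of compound 3, while compound 1 gives 1390 nM, a gap beyond the scatter. Compound 4 `O=C(O)c1ccc(S(=O)(=O)NNc2ccc(Br)cc2)cc1` differs from compound 3 in one place: carboxy in place of cyano on an aromatic carbon. Going by the values given here, no measured pair shows this change, so the size of the step is not anchored by any value in the set. The expectation for compound 4 is a weakening of moderate size, beyond the scatter, a 3.0-fold higher number from compound 3 to compound 4 (0.47 log units; beyond the scatter). Compound 4 is estimated at 400 nM, with a range from 130 nM to 1500 nM.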

Compound 4, half-maximal effective concentration: 172 nM
For compound 4 the middle estimate is 2.3-fold (0.37 log units) above the measured one; measured number inside the range.
By their numbers in this assay, from the lowest: compounds 2, 3 and 4 (each within the scatter of the next); then compound 1.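

In this assay, going by these compounds alone, carboxy in place of cyano on an aromatic carbon, para to a large group, gives a 1.3-fold higher number from compound 3 to compound 4 (0.11 log units; within the scatter) and provides the first one-place comparison. At this position, the carboxy group, with its hydrogen-bond donor, reads alike with the cyano group. No supporting measurement bears on this result. Going by these compounds, whether an amine or a methyl ester at this position would also read alike remains open. Also open, on these data alone, is whether the same exchange reads alike when the other end of the molecule differs.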